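This account rests on a few compounds, and the source may have more. Where it says the series, first, only, none or still open, it means among the compounds named here.

Measured compounds:
compound 1, `COc1cc(Cl)c(-c2nc(SCC(=O)NC3CC3)nc3[nH]cc(C#N)c23)cc1OC`: 69 nM
compound 2, `COc1cc(Cl)c(-c2nc(SCC(=O)NC3CC3)nc3[nH]cc(C#N)c23)cc1O`: 102 nM
compound 3, `COc1cc(Cl)c(-c2nc(SCC(=O)N3CCC3)nc3[nH]cc(C#N)c23)cc1O`: 21 nM

Three compounds were measured in a functional assay on BT-474 cells (Homo sapiens) for antiproliferative activity, read by sulforhodamine B assay, with a stated time of 4 days; on this read-out higher numbers stand for weaker inhibition of growth and lower numbers for stronger inhibition of growth. Compound 2 gives 102 nM. Compound 1 differs from compound 2 by methyl in place of hydrogen on an oxygen on an aromatic ring, and compound 1 gives 69 nM, a step of a 1.5-fold lower number from compound 2 to compound 1 (0.17 log units; within the scatter). Compound 3 differs from compound 2 by azetidin-1-yl in place of cyclopropylamino on a carbonyl carbon, and compound 3 gives 21 nM, a step of a 4.9-fold lower number from compound 2 to compound 3 (0.69 log units; beyond the scatter). Compound 3 has the lowest number of the three, and its steps to both others lie beyond the scatter.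

Compound 4, `COc1cc(Cl)c(-c2nc(SCC(=O)N3CCC3)nc3[nH]cc(C#N)c23)cc1OC`, has not yet been measured in this assay. It differs from compound 3 by methyl in place of hydrogen on an oxygen on an aromatic ring. This is the same change as was made from compound 2 to compound 1, at a place described in identical words, and there it gave a 1.5-fold lower number from compound 2 to compound 1 (0.17 log units; within the scatter), a step within the scatter. The two cores on which the change is made differ from one another by azetidin-1-yl in place of cyclopropylamino on a carbonyl carbon. The expectation for compound 4 rests on that single earlier step, a 1.5-fold lower number from compound 2 to compound 1 (0.17 log units; within the scatter), and nothing else. For compound 4 the expected step is a 1.4-fold lower number from compound 3 to compound 4 (0.15 log units; within the scatter), small enough to stay within the scatter. Compound 4 is therefore estimated at 15 nM, with a likely range from 6 nM to 40 nM.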

Compound 4, concentration for 50% growth inhibition: 31 nM
The estimate for compound 4 lay 2.1-fold (0.32 log units) below the measured number, within the range that was stated.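

In this assay, hydroxy to methoxy on the core bearing azetidin-1-yl gives a 1.5-fold higher number from compound 3 to compound 4 (0.17 log units; within the scatter), and this step does not differ from the one seen for the same change on the core bearing cyclopropylamino: the same change on two cores in this assay, a 1.5-fold lower number (0.17 log units; within the scatter) from compound 2 to compound 1 and a 1.5-fold higher number (0.17 log units; within the scatter) from compound 3 to compound 4, 2.2-fold (0.34 log units) apart, within the scatter of two such steps. The other change, azetidin-1-yl in place of cyclopropylamino on a carbonyl carbon, gives a 2.2-fold lower number from compound 1 to compound 4 (0.35 log units; beyond the scatter) on the methoxy core, which goes the same way as on the hydroxy core and also does not differ from it: the same change on two cores in this assay, a 4.9-fold lower number (0.69 log units; beyond the scatter) from compound 2 to compound 3 and a 2.2-fold lower number (0.35 log units; beyond the scatter) from compound 1 to compound 4, 2.2-fold (0.34 log units) apart, within the scatter of two such steps. This shows that both changes carried over between these cores within the scatter of two such steps, but the result rests on a single set of four compounds and does not show that either change would carry over to any other core, and the opposite directions of the two methyl steps are no evidence of a reversal, as both lie within the scatter.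

The compounds shown leave open how a longer chain in place of the methyl on that oxygen, or an open amine such as dimethylamino in place of azetidin-1-yl on the carbonyl carbon, would behave. They also leave open whether these steps would hold on a core with a carboxylic acid in place of the nitrile.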